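Purine benzyl chlorides: removing a ring chloro

A few compounds are considered here, and "the series" means these few. Any claim that something is new, unique, unknown or untested is made for them only; others in the source may bear on it.

Measured in a functional assay on NCI-H322M cells (Homo sapiens) for cytotoxicity, read by sulforhodamine B assay, with a stated time of 48 h; on this read-out higher numbers stand for weaker inhibition of growth and lower numbers for stronger inhibition of growth:
compound 1 `ClCc1ccc(Cn2cnc3c(Cl)ncnc32)cc1`: 4160 nM
compound 2 `ClCc1ccc(Cn2cnc3nc(Cl)nc(Cl)c32)cc1`: 1900 nM
compound 3 `ClCc1ccc(Cn2cnc3c(Cl)nc(Cl)nc32)cc1`: 25100 nM

Compound 2 has the lowest number of the three; compound 1 is nearest, compound 3 furthest, and both gaps are beyond the scatter. Compound 2 and compound 3 carry the same atoms joined differently; the difference between the two cores is not broken down here.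

One change has already been measured once: from compound 3 to compound 1 the chloro is lost, (hydrogen in place of chloro on an aromatic carbon), and the number falls, a 6.0-fold lower number from compound 3 to compound 1 (0.78 log units; beyond the scatter).

Compound 4 `ClCc1ccc(Cn2cnc3ncnc(Cl)c32)cc1`, not yet measured, stands to compound 2 as compound 1 stands to compound 3: hydrogen in place of chloro on an aromatic carbon. The two place descriptions agree word for word, so this is the same change on the other core.

Expectation for compound 4 in this assay: a fall of the same direction is expected, a 3.8-fold lower number from compound 2 to compound 4 (0.58 log units; beyond the scatter), resting on the single earlier step of a 6.0-fold lower number from compound 3 to compound 1 (0.78 log units; beyond the scatter); since that step is seen only once and on a different core, the expected step is set somewhat smaller than it. Compound 4 is thus estimated at 500 nM, with a range from 150 nM to 1600 nM expected to hold most repeat measurements.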

Compound 4, concentration for total growth inhibition: 3010 nM
Estimate against measurement, compound 4: 6.0-fold (0.78 log units) below; the measured number lies above the stated range.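

In this assay, putting hydrogen in place of chloro on an aromatic carbon gives a 1.6-fold higher number from compound 2 to compound 4 (0.20 log units; within the scatter), so on this core the change leaves no difference that can be separated from the scatter, and the chloro between the two ring nitrogen atoms can go without a measurable shift in the number. The result of this change on one core therefore does not carry over to the other core in this series: the same change on two cores in this assay, a 6.0-fold lower number (0.78 log units; beyond the scatter) from compound 3 to compound 1 and a 1.6-fold higher number (0.20 log units; within the scatter) from compound 2 to compound 4, 9.6-fold (0.98 log units) apart, beyond the scatter of two such steps

This shows that the outcome of the change depends on the core it is made on, but with a single pair per core it does not show what in the cores sets the two results apart, nor how the change would behave on any further core.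

Open, on these data alone, is whether an amine, a methoxy group or a longer chain in the place of the lost chloro would follow the pattern of the core of compound 1 or that of the core of compound 2. Also open, as far as these compounds go, is what an amine or hydrogen would do in place of the chloro that remains in compound 1 and compound 4, where each core could be tested a second time.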